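From Methyl to Methoxy on an Aromatic Ring

This account rests on a few compounds, and the source may have more. Where it says the series, first, only, none or still open, it means among the compounds named here.

Going by the values given here, only two compounds have numbers so far. In a functional assay (HSMC cells, Homo sapiens) for antiproliferative activity, with a stated time of 72 h (on this read-out higher numbers stand for weaker inhibition and lower numbers for stronger inhibition), compound 1 `COC(=O)CNC(=O)c1ccc(C(=O)NC[C@H]2COc3ccccc3O2)cc1-c1ccccc1OC` gives 122000 nM as its reading, and compound 2 `COC(=O)[C@H](CC(C)C)NC(=O)c1ccc(C(=O)NC[C@H]2COc3ccccc3O2)cc1-c1ccccc1C` gives 103000 nM as its reading. These two values lie within the usual scatter of repeated measurements, so compound 2 stands level with compound 1 and neither can be ranked ahead.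

The next molecule, compound 3 `COC(=O)[C@H](CC(C)C)NC(=O)c1ccc(C(=O)NC[C@H]2COc3ccccc3O2)cc1-c1ccccc1OC`, matches compound 2 except at one spot: methoxy in place of methyl on an aromatic carbon, ortho to a large group, which turns 2-methylphenyl into 2-methoxyphenyl methoxy in place of methyl on an aromatic carbon in the structure.

Among the compounds with values here, no measured pair isolates this change, so its size in this assay cannot be read directly. One hint exists: compound 1 also carries 2-methoxyphenyl, differs elsewhere as well, and gives 122000 nM as its value, level with compound 2. No step beyond the scatter is therefore expected in either direction, and the estimated change is a 1.0-fold higher number from compound 2 to compound 3 (0.01 log units; within the scatter) in size. For compound 3 the expected value is 105000 nM as a middle figure, with an estimated range from 50000 nM to 200000 nM across repeated measurements.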

Compound 3, half-maximal inhibitory concentration: 185000 nM
The estimate for compound 3 lay 1.8-fold (0.25 log units) below the measured number, and the stated range covers the measured number.
By their numbers in this assay, from the lowest: compounds 2, 1 and 3 (each within the scatter of the next).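

Going by these compounds alone, the swap of methyl for methoxy on this aromatic carbon, ortho to a large group, now has a direct measurement for the first time: in this assay it gives a 1.8-fold higher number from compound 2 to compound 3 (0.25 log units; within the scatter) and is therefore not distinguishable from repeat-to-repeat variation. Compound 1 and compound 3 both carry 2-methoxyphenyl, which allows a second direct comparison, where isobutyl replaces hydrogen on a saturated chain carbon bound to an amide-type nitrogen and a carbonyl carbon; this gives a 1.5-fold higher number from compound 1 to compound 3 (0.18 log units; within the scatter) and again no separable effect in this single pair. No independent measurement is available to help interpret these readings beyond the numbers themselves.

Going by these compounds, whether a different substituent on the same aromatic carbon, such as a hydroxyl group, an ethoxy group or a chlorine atom, would produce a step beyond the scatter remains open. On these data alone, it also remains open whether a larger change elsewhere on the shared core, such as a carboxylic acid or an amine, would shift the reading in this assay by more than the steps seen here.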